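Swapping trifluoromethyl for chloro in a urea-linked pyrazole series

This account rests on a few compounds, and the source may have more. Where it says the series, first, only, none or still open, it means among the compounds named here.

Measured so far:
compound 1, `O=C(Nc1cccc(-n2cc(-c3ccncc3)c(-c3cc(O)cc(Cl)c3)n2)c1)Nc1ccc(Cl)c(C(F)(F)F)c1`, 47.6%
compound 2, `O=C(Nc1cccc(-n2cc(-c3ccncc3)c(-c3cc(O)cc(Cl)c3)n2)c1)Nc1ccc(Cl)c(Cl)c1`, 0.54%
compound 3, `COc1cc(Cl)cc(-c2nn(-c3cccc(NC(=O)Nc4ccc(Cl)c(C(F)(F)F)c4)c3)cc2-c2ccncc2)c1`, 9.81%

In a functional assay on BT-549 cells (Homo sapiens) for inhibition, read by sulforhodamine B assay, with a stated time of 48 h, tested at 10 uM (a higher number here means a weaker effect of the compound at the concentration tested, a lower number a stronger effect), compound 1 gives the highest of the three numbers. Compound 2 differs from compound 1 only by chloro in place of trifluoromethyl on an aromatic carbon, and this single change produces a number 47.1 percentage points lower from compound 1 to compound 2 (beyond the scatter). Compound 3 differs from compound 1 by methyl in place of hydrogen on an oxygen on an aromatic ring, which gives a number 37.8 percentage points lower from compound 1 to compound 3 (beyond the scatter). Compound 2 and compound 3 lie within the usual scatter of each other, so no order between them can be claimed.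

Compound 4, `COc1cc(Cl)cc(-c2nn(-c3cccc(NC(=O)Nc4ccc(Cl)c(Cl)c4)c3)cc2-c2ccncc2)c1`, has not been measured. Relative to compound 3 it carries chloro in place of trifluoromethyl on an aromatic carbon; the place around the changed carbon reads the same as in the step from compound 1 to compound 2, so this is the same change on a core that differs by the methyl on the oxygen. The earlier step was large, but compound 3 gives 9.81%, which is a low number in this read-out, so only a modest further fall is expected. The step from compound 3 to compound 4 is estimated as a number 7.8 percentage points lower from compound 3 to compound 4 (within the scatter), resting on the earlier step of a number 47.1 percentage points lower from compound 1 to compound 2 (beyond the scatter). Compound 4 is therefore estimated at 2%, between -6% and 10%.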

Compound 4, a percentage reported as activity, at one concentration (the size of the read-out at that concentration, not a potency): 29.4%
For compound 4 the middle estimate is 27.4 percentage points below the measured one; the whole stated range lies below it.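

In this assay, chloro in place of trifluoromethyl gives a number 19.6 percentage points higher from compound 3 to compound 4 (beyond the scatter), so the change does not carry over from the core of compound 1 to the core of compound 3, and its direction reverses: the same change on two cores in this assay, a number 47.1 percentage points lower (beyond the scatter) from compound 1 to compound 2 and a number 19.6 percentage points higher (beyond the scatter) from compound 3 to compound 4, 66.7 percentage points apart, beyond the scatter of two such steps

Methyl in place of hydrogen on the oxygen gives a number 28.9 percentage points higher from compound 2 to compound 4 (beyond the scatter), and this change also reverses between its two cores: the same change on two cores in this assay, a number 37.8 percentage points lower (beyond the scatter) from compound 1 to compound 3 and a number 28.9 percentage points higher (beyond the scatter) from compound 2 to compound 4, 66.7 percentage points apart, beyond the scatter of two such steps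

Both comparisons come from the same four compounds, so together they are a single observation that the effect of each change depends on the other position in this set, but they do not show why, nor do they give a rule for other compounds in the series.

The compounds shown leave open whether a bromo or nitrile group in place of chloro would also depend on the group on the oxygen. As far as these compounds go, it also remains open how a longer chain, such as ethyl or propyl, would behave on that oxygen.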